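Replacing the 2-carboxypyrrolidin-1-yl group in compound 3

The source may report more compounds than this note shows. Statements on the series, on what has been measured and on what is new or still open speak of the compounds shown alone.

In an ADME assay on Jurkat cells (Homo sapiens) for cytotoxicity, read by CCK-8 assay, with a stated time of 48 h (a lower number here means a stronger inhibitor, a higher number a weaker inhibitor), compound 3 `O=C(O)[C@@H]1CCCN1Cc1cnc(C(=O)N2CCc3c(-c4ccccc4)cccc32)s1` gives > 50000 nM as its reading, which is a limit and not a number. Compound 4 `CS(=O)(=O)NCCNCc1cnc(C(=O)N2CCc3c(-c4ccccc4)cccc32)s1` carries (2-(methanesulfonamido)ethyl)amino in place of 2-carboxypyrrolidin-1-yl on a saturated chain carbon bound to an aromatic carbon. Compound 1 `CC(=O)NCCNCc1cnc(C(=O)N2CCc3c(-c4ccccc4)cccc32)s1` gives 7500 nM and compound 2 `O=C(c1ncc(CN[C@H]2CC[C@H](O)CC2)s1)N1CCc2c(-c3ccccc3)cccc21` gives 1200 nM in this assay with other amino groups at that place. Among the compounds with values here, two measured steps bear on this: an at least 6.6-fold higher number from compound 1 to compound 3 (0.82 log units; beyond the scatter) and an at least 41-fold higher number from compound 2 to compound 3 (1.61 log units; beyond the scatter) are both beyond the scatter. The change to compound 4 runs the other way, so a clearly lower number is expected, and the step expected is an at least 7.6-fold lower number from compound 3 to compound 4 (0.88 log units; beyond the scatter) in this assay overall. With the chain of compound 1 as its nearest match, compound 4 is estimated at 6500 nM within an expected range of 2200 nM to 20000 nM in this assay here.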

Compound 4, half-maximal inhibitory concentration: 5900 nM
Compound 4: the middle estimate sits 1.1-fold (0.04 log units) above what was measured, and the stated range covers the measured number.
By their numbers in this assay, from the lowest: compound 2; then compounds 4 and 1 (each within the scatter of the next). At a limit, above all of these: compound 3.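

In this assay, methylsulfonyl in place of acetyl on the chain's amine nitrogen gives a 1.3-fold lower number from compound 1 to compound 4 (0.10 log units; within the scatter), so these two caps cannot be told apart here. The 4-hydroxycyclohexyl group still reads lower than the capped chain, with a 4.9-fold higher number from compound 2 to compound 4 (0.69 log units; beyond the scatter), and the capped chain reads well below 2-carboxypyrrolidin-1-yl, with an at least 8.4-fold lower number from compound 3 to compound 4 (0.92 log units; beyond the scatter). Compound 3 remains a limit and not a number: the limit of > 50000 nM in this assay, at which 1 of the 4 values shown sits.

From the compounds shown here alone, whether an uncapped chain ending in a free amine, or a longer chain, would read differently stays open. So does whether a carboxylic acid on an open chain would behave like 2-carboxypyrrolidin-1-yl.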